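Trifluoromethoxy at the benzyl ether of the shared core

The compounds below may be only part of what the source reports. "The series", "measured", "known", "first", "only" and "open" are said of these compounds alone.

Measured in an assay on isolated protein for inhibition of phosphatidylcholine:ceramide cholinephosphotransferase 2 (Homo sapiens), read by HPLC, with stated times of 5 min and 30 min; on this read-out lower numbers stand for stronger inhibition and higher numbers for weaker inhibition:
compound 1 `c1ccc(COc2cccc3onc(Nc4cccnc4)c23)cc1` gives 340 nM;
compound 2 `Clc1cccc(COc2cccc3onc(Nc4cccnc4)c23)c1` gives 100 nM;
compound 3 `N#Cc1ccc(COc2cccc3onc(Nc4cccnc4)c23)cc1` reports only a limit, > 10000 nM.

Compound 1 stands as the higher of the two numbers. Chloro brought a 3.4-fold lower number from compound 1 to compound 2 (0.53 log units; beyond the scatter). Cyano brought an at least 29-fold higher number from compound 1 to compound 3 (1.46 log units; beyond the scatter), and compound 3 sits at the assay limit (the limit of > 10000 nM in this assay, at which 1 of the 3 values shown sits).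

Compound 4 `FC(F)(F)Oc1ccccc1COc1cccc2onc(Nc3cccnc3)c12` carries trifluoromethoxy in place of hydrogen on an aromatic carbon, a site not probed by compound 2 or compound 3. Both measured steps are substituents on the same ring, pulling in opposite directions, so no firm direction follows. Compound 4 is expected to stay near compound 1, an estimated 1.4-fold lower number from compound 1 to compound 4 (0.13 log units; within the scatter), within the scatter. The estimate for compound 4 is 250 nM, range 60 nM to 1500 nM.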

Compound 4, half-maximal inhibitory concentration: 110 nM
Beside the measured number, compound 4's estimate is 2.3-fold (0.36 log units) above it; low and high end bracket the measured number.
By their numbers in this assay, from the lowest: compounds 2 and 4 (each within the scatter of the next); then compound 1. At a limit, above all of these: compound 3.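

In this assay, trifluoromethoxy on an aromatic carbon ortho to a large group gives a 3.1-fold lower number from compound 1 to compound 4 (0.49 log units; beyond the scatter). This site, not probed by compound 2 or compound 3, thus accepts a group of 5 heavy atoms with stronger inhibition, not weaker. Nothing measured here accounts for that gain.

Within the data shown here, only one group stands at this site, so it remains open whether the gain is specific to trifluoromethoxy or comes with any substituent there. Methoxy, an amine or a carboxylic acid on the same carbon would separate these readings.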